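A few compounds are considered here, and "the series" means these few. Any claim that something is new, unique, unknown or untested is made for them only; others in the source may bear on it.

Compound 3, `O=C1c2ccccc2N(Cc2ccc([N+](=O)[O-])cc2)S(=O)(=O)N1Cc1ccccc1`, is the point of departure. In a functional assay on MRC5 cells (Homo sapiens) (a lower number here means that less compound is tolerated, a higher number that more compound is tolerated), compound 3 gives > 59000 nM, which is a limit of the assay rather than a measured number. Two measured neighbours differ from it in one place. Compound 1, `O=C1c2ccccc2N(Cc2ccc([N+](=O)[O-])cc2)S(=O)(=O)N1Cc1ccc([N+](=O)[O-])cc1`, carries a second nitro group and gives 53000 nM in this assay; the step of an at least 1.1-fold higher number from compound 1 to compound 3 (0.04 log units; that floor lies within the scatter) lies within the scatter. Compound 2, `O=C1c2ccccc2N(Cc2ccc(C(F)(F)F)cc2)S(=O)(=O)N1Cc1ccccc1`, carries a trifluoromethyl in place of the nitro group of its neighbour, and in this assay compound 2 gives 56000 nM; the step of an at least 1.0-fold higher number from compound 2 to compound 3 (0.02 log units; that floor lies within the scatter) likewise lies within the scatter. Compound 3 thus stands at the limit of > 59000 nM in this assay, at which 1 of the 3 values shown sits, with no number of its own, and both of its neighbours sit close to that limit.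

Compound 4, `O=C1c2ccccc2N(Cc2ccccc2Cl)S(=O)(=O)N1Cc1ccccc1`, differs from compound 3 by 2-chlorophenyl in place of 4-nitrophenyl on a saturated chain carbon bound to a sulfonamide nitrogen in a ring. Both measured steps varied a substituent on a benzyl group, and neither moved the read-out beyond the scatter. Compound 4 is therefore expected to show a step of an at least 1.0-fold lower number from compound 3 to compound 4 (0.03 log units; that floor lies within the scatter) that stays within the scatter. Compound 4 is estimated at 55000 nM, within 30000 nM to 100000 nM, with a real chance that this assay once more reports only a limit.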

Compound 4, half-maximal cytotoxic concentration: 60000 nM
Estimate against measurement, compound 4: 1.1-fold (0.04 log units) below; the range from low to high includes it.
By their numbers in this assay, from the lowest: compounds 1, 2 and 4 (each within the scatter of the next).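

The change of 4-nitrophenyl to 2-chlorophenyl on a saturated chain carbon bound to a sulfonamide nitrogen in a ring gives this place its first exchange in which the substituent on the phenyl ring is neither nitro nor trifluoromethyl and the ring carries it under a different name, 2-chloro rather than 4-substituted. In this assay, the comparison with the trifluoromethyl compound gives a 1.1-fold higher number from compound 2 to compound 4 (0.03 log units; within the scatter), so this exchange, too, leaves the read-out within the scatter, and compound 4 supplies a number of its own at this place where compound 3 has none. The step between compound 3 and compound 4 cannot be read because compound 3 stands at a limit of the assay: the limit of > 59000 nM in this assay, at which 1 of the 4 values shown sits.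

The compounds shown leave open whether any change at this place can move the read-out beyond the scatter, for instance an amine or a carboxylic acid on the phenyl ring, or a longer chain in place of the benzyl group. They also leave open how far the true value of compound 3 lies from its limit.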